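Para-halogen scan on the pyrazoline series: chloro analogue

The source may hold more compounds than are shown below. What is called first, only, known or untested is meant among the compounds shown, and "the series" means these compounds.

Measured so far:
- compound 1 `Fc1ccc(C2=NN(c3ccccc3)C(c3ccc4ccccc4c3)C2)cc1`: 850 nM
- compound 2 `c1ccc(C2=NN(c3ccccc3)C(c3ccc4ccccc4c3)C2)cc1`: 730 nM

Both compounds were tested in a functional assay on MCF7 cells (Homo sapiens) for antiproliferative activity, read by MTT assay, with a stated time of 24 h; a higher number here means a weaker inhibitor of growth, a lower number a stronger inhibitor of growth. Compound 2 stands as the lower of the two numbers, but its nearest neighbour is compound 1, and the step of a 1.2-fold lower number from compound 1 to compound 2 (0.07 log units; within the scatter) lies within the scatter, so the two cannot be ordered against each other.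

The next compound, compound 3 `Clc1ccc(C2=NN(c3ccccc3)C(c3ccc4ccccc4c3)C2)cc1`, has not yet been measured in this assay. It differs from compound 2 by chloro in place of hydrogen on an aromatic carbon. Read one bond further out, the change is phenyl to 4-chlorophenyl, at the same position that carries fluoro in compound 1.

For the measured compounds named here, the only step that bears on this is a 1.2-fold lower number from compound 1 to compound 2 (0.07 log units; within the scatter): swapping a halogen for hydrogen at this position left the number essentially unchanged. On that basis no step beyond the scatter is expected in this assay for the reverse direction with chloro, and the expected step is a 1.1-fold lower number from compound 2 to compound 3 (0.05 log units; within the scatter). Compound 3 is therefore estimated at 650 nM, with a range of 300 nM to 1500 nM.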

Compound 3, concentration for 50% growth inhibition: 530 nM
Compound 3: middle estimate off by 1.2-fold (0.09 log units), on the high side; low and high end bracket the measured number.
By their numbers in this assay, from the lowest: compounds 3, 2 and 1 (each within the scatter of the next).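

In this assay, the third substituent at this position, para to a large group, again gives no separation from the others, with a 1.4-fold lower number from compound 2 to compound 3 (0.14 log units; within the scatter) for the phenyl to 4-chlorophenyl change and a 1.6-fold lower number from compound 1 to compound 3 (0.21 log units; within the scatter) for the exchange of one halogen for the other. The earlier pair showed only that fluoro and hydrogen could not be told apart; hydrogen, fluoro and chloro now all fall within the scatter of one another, and even the largest step in the set stays within it, so the three cannot be ordered and no halogen trend can be claimed from these compounds. Nothing available on the series accounts for this flat reading or for the small differences in the numbers.

Still open, from the compounds shown here alone, is whether the position stays this flat for groups unlike the halogens, such as an amine, a carboxylic acid, a methoxy group or a longer alkyl chain, any of which could test the limits of the tolerance seen here. Also open, going by these compounds, is whether bromo or iodo at the same place would remain within the scatter of compound 3, and whether a change elsewhere on the shared core would move the number further than any change at this position has so far.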